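Replacing 4-methylphenyl with pyridin-2-yl

A few compounds are considered here, and "the series" means these few. Any claim that something is new, unique, unknown or untested is made for them only; others in the source may bear on it.

In a functional assay on MCF7 cells (Homo sapiens) for cytotoxicity, read by ELISA, with a stated time of 4 days (on this read-out higher numbers stand for weaker inhibition and lower numbers for stronger inhibition), compound 1 (`Cc1ccsc1-c1cc(-c2ccoc2)cc(-c2ccc(Cl)cc2)n1`) gives 20300 nM and compound 2 (`Cc1ccc(-c2cc(-c3ccoc3)cc(-c3ccc(Cl)s3)n2)cc1`) gives 5340 nM as its result. Compound 2 thus holds the lower number of the two, by a gap beyond the usual scatter of repeat measurements. Compound 3 (`Clc1ccc(-c2cc(-c3ccoc3)cc(-c3ccccn3)n2)s1`) differs from compound 2 in one place: pyridin-2-yl in place of 4-methylphenyl on an aromatic carbon. Compound 1 and compound 2 differ from each other in more than one place, so their gap gives no direct guide to this swap. Going by the values given here, with no measured step to lean on, the expectation stays close to compound 2 at 5340 nM with no step beyond the scatter, in either direction, in this assay once tested. The expected change is small (a 1.1-fold higher number from compound 2 to compound 3 (0.05 log units; within the scatter)) in size. The estimate for compound 3 is 6000 nM and it is expected to fall between 2000 nM and 18000 nM.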

Compound 3, half-maximal inhibitory concentration: 3360 nM
Compound 3: the middle estimate sits 1.8-fold (0.25 log units) above what was measured; measured number inside the range.
By their numbers in this assay, from the lowest: compounds 3 and 2 (each within the scatter of the next); then compound 1.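

Putting pyridin-2-yl in place of 4-methylphenyl gives a 1.6-fold lower number from compound 2 to compound 3 (0.20 log units; within the scatter) in this assay, the first single-place step read at this position, next to the ring nitrogen of the core. The position therefore takes a ring with a nitrogen in place of a ring of carbon only, and a hydrogen-bond acceptor where the old group had none, without a shift that stands out from repeat-measurement noise. No measurement at hand explains this result or says what, if anything, the ring nitrogen contributes here.

As far as these compounds go, whether a larger change at this position, such as a longer chain in place of the ring, would move the number beyond the scatter remains open. So does the effect of an amine or a carboxylic acid attached to the pyridin-2-yl ring.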